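A Methyl Added to the Linker Chain of Compound 1

The source may hold more compounds than are shown below. What is called first, only, known or untested is meant among the compounds shown, and "the series" means these compounds.

Compound 1 `CC1=C(CCC(=O)OCCCCOc2no[n+]([O-])c2S(=O)(=O)c2ccccc2)C(=O)c2c(O)cccc2C1=O` gives 1240 nM in a functional assay on MDA-MB-231 cells (Homo sapiens) for inhibition, read by MTT assay, with a stated time of 72 h (a lower number here means a stronger inhibitor, a higher number a weaker inhibitor), the higher of the two numbers measured, with compound 2 `CC1=C(CCC(=O)OCCOc2no[n+]([O-])c2S(=O)(=O)c2ccccc2)C(=O)c2c(O)cccc2C1=O` close to it at 1210 nM; the two lie within the usual scatter, so neither can be called the stronger. Compound 3 `CC1=C(C(C)CC(=O)OCCCCOc2no[n+]([O-])c2S(=O)(=O)c2ccccc2)C(=O)c2c(O)cccc2C1=O` has not been measured; it differs from compound 1 by methyl in place of hydrogen on a saturated chain carbon bound to a double-bonded ring carbon and a saturated chain carbon. Going by the values given here, no step between measured compounds offers a precedent for this change. Compound 3 is expected to stay close, with a step of a 1.0-fold higher number from compound 1 to compound 3 (0.02 log units; within the scatter) that likely falls within the scatter in either direction. Compound 3 is therefore estimated at 1300 nM, in the range 600 nM to 2800 nM.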

Compound 3, half-maximal inhibitory concentration: 1980 nM
Estimate against measurement, compound 3: 1.5-fold (0.18 log units) below; measured number inside the range.
By their numbers in this assay, from the lowest: compounds 2, 1 and 3 (each within the scatter of the next).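

In this assay, methyl in place of hydrogen on this saturated chain carbon gives a 1.6-fold higher number from compound 1 to compound 3 (0.20 log units; within the scatter). Going by these compounds alone, this is the first step read at this carbon, and it shows that the added methyl leaves the number within the scatter of compound 1. Nothing available explains the size of this step.

From the compounds shown here alone, it remains open whether an ethyl group, a hydroxyl group or an amine on the same carbon would carry the number beyond the scatter. Going by these compounds, it is also open whether the methyl would give a similar step on the linker of compound 2.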